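Replacing the Ethoxy Group with a Triazole

The source may hold more compounds than are shown below. What is called first, only, known or untested is meant among the compounds shown, and "the series" means these compounds.

The series rests on a shared core carrying a pentylamino chain linked through two ether oxygens to a benzene ring. In a functional assay on SK-OV-3 cells (Homo sapiens) for inhibition, read by CCK-8 assay, with a stated time of 70 h (a higher number here means a weaker inhibitor, a lower number a stronger inhibitor), compound 1 `Clc1ccc(COc2ccc(OCCOCCNC3CCCC3)cc2)cc1` gives 7670 nM, while compound 2 `CCOc1ccc(OCCOCCNC2CCCC2)cc1` gives 90500 nM, the highest number of the two measured. Within the data shown here, the one step measured so far, a 12-fold higher number from compound 1 to compound 2 (1.07 log units; beyond the scatter), shows that the group on this aromatic carbon matters a great deal in this assay.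

Compound 3 `c1ncn(-c2ccc(OCCOCCNC3CCCC3)cc2)n1` changes the same position again: 1H-1,2,4-triazol-1-yl in place of ethoxy on an aromatic carbon. Among the measured compounds shown here, no measured step covers this exact exchange, so the step from compound 1 to compound 2 is the only guide, and it shows that a larger group at this position went with a far lower number. The triazole is larger than ethoxy but smaller than 4-chlorophenyl, so the direction is more likely toward a lower number than toward a higher one, with wide uncertainty. The step expected is a 2.3-fold lower number from compound 2 to compound 3 (0.35 log units; beyond the scatter). Compound 3 is therefore estimated at 40000 nM, within a range from 10000 nM to 150000 nM.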

Compound 3, half-maximal inhibitory concentration: > 100000 nM
Compound 3 was reported as a limit (the forecaster's own chance of this, stated with the estimate: 15%); middle value at least 2.5-fold (0.39 log units) from the limit.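

Compound 3 is reported in this assay only as a limit of the assay, not as a number: the limit of > 100000 nM in this assay, at which 1 of the 3 values shown sits.

In place of ethoxy, 1H-1,2,4-triazol-1-yl gives an at least 1.1-fold higher number from compound 2 to compound 3 (0.04 log units; that floor lies within the scatter), so this floor alone does not set the two compounds apart, and the real size of the step cannot be read. In place of (4-chlorobenzyl)oxy, the same group gives an at least 13-fold higher number from compound 1 to compound 3 (1.11 log units; beyond the scatter), which shows that a larger group than ethoxy on this aromatic carbon does not by itself bring the number down, and that the lower number seen so far belongs to the (4-chlorobenzyl)oxy group of compound 1 alone among these three compounds.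

The compounds shown leave open which part of that group carries the effect, the chlorine, the benzene ring or the oxygen and methylene that link it, as a plain benzyloxy or a 4-chlorophenoxy group would help to tell. They also leave open how a simple amine or a carboxylic acid on this aromatic carbon would read in this assay.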